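Cyclic amide trimmed to dimethylamide in a cathepsin S series

The compounds below may be only part of what the source reports. "The series", "measured", "known", "first", "only" and "open" are said of these compounds alone.

Measured compounds:
- compound 1, `N#CC1(NC(=O)[C@@H]2C[C@@H](S(=O)(=O)c3ccccc3)C[C@H]2C(=O)N2CCOCC2)CCC1`: 4 nM
- compound 2, `C[C@@H]1CN(C(=O)[C@@H]2C[C@H](S(=O)(=O)c3ccccc3)C[C@H]2C(=O)NC2(C#N)CC2)C[C@H](C)O1`: 0.4 nM
- compound 3, `CN1CCN(C(=O)[C@@H]2C[C@H](S(=O)(=O)c3ccccc3)C[C@H]2C(=O)NC2(C#N)CC2)CC1`: 2 nM

The three measured compounds share a core carrying a phenylsulfonyl group and a nitrile-bearing amide, and differ mainly in the amide attached to the other carbonyl. In an assay on isolated protein for inhibition of cathepsin S (Homo sapiens), read by fluorescence, with a stated time of 20 min (on this read-out lower numbers stand for stronger inhibition and higher numbers for weaker inhibition), compound 3 gives 2 nM, the second highest of the three numbers. Its nearest neighbour is compound 1, which gives 4 nM in this assay, a gap within the scatter. Within the data shown here, the one step that bears on the amide is a 5.0-fold higher number from compound 2 to compound 3 (0.70 log units; beyond the scatter), so a change at this carbonyl has already shifted the number by a modest amount.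

Compound 4, `CN(C)C(=O)[C@@H]1C[C@H](S(=O)(=O)c2ccccc2)C[C@H]1C(=O)NC1(C#N)CC1`, is not yet measured. The change from compound 3 is dimethylamino in place of 4-methylpiperazin-1-yl on a carbonyl carbon. Among the measured compounds shown here, the only precedent is the step from compound 2 to compound 3, and it went toward a higher number as the amide changed; nothing here shows a smaller, acyclic group at this carbonyl. The expectation is therefore a small step, a 1.5-fold higher number from compound 3 to compound 4 (0.18 log units; within the scatter), toward a somewhat higher number or none beyond the scatter. Compound 4 is estimated at 3 nM in this assay, within the range 1 nM to 10 nM.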

Compound 4, half-maximal inhibitory concentration: 6 nM
Compound 4: middle estimate off by 2.0-fold (0.30 log units), on the low side; the range from low to high includes it.
By their numbers in this assay, from the lowest: compound 2; then compounds 3, 1 and 4 (each within the scatter of the next, the first and the last beyond it).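

In this assay, among these compounds, dimethylamino is the first group without a ring at this carbonyl carbon, and exchanging 4-methylpiperazin-1-yl for it gives a step that lies beyond the scatter (a 3.0-fold higher number from compound 3 to compound 4 (0.48 log units; beyond the scatter)). Exchanging 2,6-dimethylmorpholin-4-yl for the same group gives a large step (a 15-fold higher number from compound 2 to compound 4 (1.18 log units; beyond the scatter)), whereas the earlier exchange of that group for 4-methylpiperazin-1-yl gave only a modest one. Among compound 2, compound 3 and compound 4, which differ only in this group, both ring-bearing groups therefore give lower numbers than dimethylamino, and the position responds to the group's identity over a wider span than the earlier compounds showed, although three groups are a narrow basis and compound 1 differs in more than one place.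

The compounds shown leave open whether a longer open chain such as diethylamino, or a simpler ring such as unsubstituted morpholin-4-yl or piperidin-1-yl, would stand with dimethylamino or with the ring-bearing groups at this carbonyl carbon. Nothing given here accounts for why the number shifts with these groups.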